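The source may report more compounds than this note shows. Statements on the series, on what has been measured and on what is new or still open speak of the compounds shown alone.

Compound 1 `COc1cccc(OCC(=O)Nc2cccc(NC(=O)c3ccc(N(C)C)cc3)c2)c1` gives 5740 nM in an assay on isolated protein for inhibition of Rho-associated protein kinase 2 (Homo sapiens), read by scintillation counting, radiometric assay and 33P incorporation, with a stated time of 40 min, in the presence of a further agent that is not named here; a lower number here means a stronger inhibitor, a higher number a weaker inhibitor.
Compound 2 `CCc1ccc(C(=O)Nc2cccc(NC(=O)COc3ccc4c(=O)ccoc4c3)c2)cc1` gives 24 nM in this assay.

Of the two measured compounds, compound 2 carries the lower number and is therefore the stronger inhibitor; compound 1 stands far above it, and that gap lies well beyond the usual scatter of repeated measurements. The two structures differ in several places at once, so the gap cannot be laid on any single change.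

Compound 3 `CC(C)(C)c1cc(C(=O)Nc2cccc(NC(=O)COc3ccc4c(=O)ccoc4c3)c2)no1` has not yet been measured. It keeps the whole of compound 2 except at one spot: 5-(tert-butyl)-1,2-oxazol-3-yl in place of 4-ethylphenyl on a carbonyl carbon. Among the measured compounds shown here, no measured pair in this set shows an exchange of this kind, so the data give no direct guide to how large the effect will be or in which direction it runs. A cautious view is that the carbonyl-linked group can change without moving the number a great deal.

Compound 3 is therefore expected to give roughly 60 nM in this assay, with a likely range from 15 nM to 300 nM. The expected step of a 2.5-fold higher number from compound 2 to compound 3 (0.40 log units; beyond the scatter) is a modest rise in the number, close to or only just beyond the scatter.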

Compound 3, half-maximal inhibitory concentration: 5 nM
Compound 3: the middle estimate sits 12-fold (1.08 log units) above what was measured; measured number below the stated range.
By their numbers in this assay, from the lowest: compound 3; then compound 2; then compound 1.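

Among the compounds shown here, at the carbonyl carbon whose other neighbour is an amide-type nitrogen, 5-(tert-butyl)-1,2-oxazol-3-yl in place of 4-ethylphenyl gives a 4.8-fold lower number from compound 2 to compound 3 (0.68 log units; beyond the scatter) in this assay and is the only change in this set made at a single place. It shows that this position accepts more than one kind of group: a six-membered aromatic ring of carbon only can give way to a five-membered aromatic ring with 2 hetero atoms, and the inhibitor becomes stronger, not weaker. Nothing measured here accounts for the gain, so it cannot be assigned to the new ring, to the tert-butyl group or to the hydrogen-bond acceptors that enter with them.

From the compounds shown here alone, the ring and the tert-butyl group change together, so their separate shares remain unknown; a 4-(tert-butyl)phenyl group or a 5-methyl-1,2-oxazol-3-yl group on the same carbonyl would begin to pull them apart. Going by these compounds, it also remains open whether the same exchange would lower the number on a different core, such as the core of compound 1.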